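The compounds below may be only part of what the source reports. "The series", "measured", "known", "first", "only" and "open" are said of these compounds alone.

Compound 1 `CO/N=C(\c1ccc(Cl)cc1)C(O)CN1CCN(c2ccccn2)CC1` and compound 3 `Cc1cccc(/C(=N\O)C(O)CN2CCN(c3ccccn3)CC2)c1` carry different cores; how the two cores differ is not broken down here. In a functional assay on HEK293 cells with D(4) dopamine receptor (Homo sapiens) as the target, read by FLIPR (on this read-out higher numbers stand for an effect only at larger amounts of compound and lower numbers for an effect already at smaller amounts), compound 1 gives 46 nM, and in this assay compound 3 gives 44.8 nM. These two numbers lie within the usual scatter of each other, so the account treats them as alike. Compound 2 `CO/N=C(\c1ccc(Cl)cc1)C(CN1CCN(c2ccccn2)CC1)OC` differs from compound 1 by methyl in place of hydrogen on an oxygen on a saturated carbon. In this assay compound 2 gives 195 nM, which is a 4.2-fold higher number from compound 1 to compound 2 (0.63 log units; beyond the scatter). Compound 4 `COC(CN1CCN(c2ccccn2)CC1)/C(=N/O)c1cccc(C)c1` has not yet been measured; it differs from compound 3 by methyl in place of hydrogen on an oxygen on a saturated carbon, the same change, made on the core of compound 3 instead of the core of compound 1, and the place in both cases is the same word for word. This change occurs two times among the compounds here and has been measured once. Because in this assay compound 1 gives 46 nM and compound 3 gives 44.8 nM, and because the change from compound 1 to compound 2 made a 4.2-fold higher number from compound 1 to compound 2 (0.63 log units; beyond the scatter), the expectation for compound 4 is a step of about the same size. The estimated step from compound 3 to compound 4 is therefore a 4.2-fold higher number from compound 3 to compound 4 (0.63 log units; beyond the scatter) in this assay. On that basis compound 4 is expected to give about 190 nM in this assay, with a plausible range from 80 nM to 450 nM; this rests on a single measured instance of the change, so the range is kept wide.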

Compound 4, half-maximal effective concentration: 5370 nM
The estimate for compound 4 lay 28-fold (1.45 log units) below the measured number, outside the stated range (above it).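

In this assay the change from hydroxy to methoxy, methyl in place of hydrogen on an oxygen on a saturated carbon, gives a 120-fold higher number from compound 3 to compound 4 (2.08 log units; beyond the scatter), and this step does not match the earlier one in size: the same change on two cores in this assay, a 4.2-fold higher number (0.63 log units; beyond the scatter) from compound 1 to compound 2 and a 120-fold higher number (2.08 log units; beyond the scatter) from compound 3 to compound 4, 28-fold (1.45 log units) apart, beyond the scatter of two such steps

Both steps run in the same direction, towards a higher number, so the two measured instances agree on the sign of the change, but the size found on the core of compound 1 did not carry over to the core of compound 3. This does not show which difference between the two cores sets the size of the step, and two instances give no rule for what the change would do on a third core.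

The compounds shown leave open whether an ethyl group or an acetyl group in place of the methyl on that oxygen would give a step closer to the one on the core of compound 1 or to the one on the core of compound 3. They also leave open how the same change would read on a core that differs from the core of compound 3 in one place only.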